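This account rests on a few compounds, and the source may have more. Where it says the series, first, only, none or still open, it means among the compounds named here.

Measured so far in a functional assay on MCF7 cells (Homo sapiens) for inhibition, read by MTT assay, with a stated time of 48 h; on this read-out lower numbers stand for stronger inhibition and higher numbers for weaker inhibition:
compound 1 `COc1cc(N(Cc2nc3ccccc3[nH]2)C(=O)c2cccc(Cl)c2)cc(OC)c1OC`, 34900 nM;
compound 2 `COc1cc(N(Cc2nc3ccccc3[nH]2)C(=O)c2ccc(C)cc2)cc(OC)c1OC`, 49300 nM.

Compound 2 stands at the highest of the two numbers shown, but the step of a 1.4-fold higher number from compound 1 to compound 2 (0.15 log units; within the scatter) lies within the scatter, so the two are not separated. Compound 3 `COc1cc(N(Cc2nc3ccccc3[nH]2)C(=O)c2ccc(C(C)(C)C)cc2)cc(OC)c1OC` differs from compound 2 by tert-butyl in place of methyl on an aromatic carbon. Among the compounds with values here, no measured step bears on this change: the single step recorded concerns other groups at another place and gives no direction. In this assay the expected step is therefore a 1.0-fold lower number from compound 2 to compound 3 (0.00 log units; within the scatter), none beyond the scatter. For compound 3 the estimate in this assay is 49000 nM, with a range from 20000 nM to 120000 nM.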

Compound 3, half-maximal inhibitory concentration: 48800 nM
Compound 3: middle estimate off by 1.0-fold (0.00 log units), on the high side, within the range that was stated.
By their numbers in this assay, from the lowest: compounds 1, 3 and 2 (each within the scatter of the next).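

Replacing methyl with tert-butyl on this aromatic carbon, para to a large group, gives (a 1.0-fold lower number from compound 2 to compound 3 (0.00 log units; within the scatter)) in this assay, so the two groups are not separated at this position despite the added heavy atoms. Replacing 3-chlorophenyl with 4-(tert-butyl)phenyl on the carbonyl carbon gives (a 1.4-fold higher number from compound 1 to compound 3 (0.15 log units; within the scatter)), which also leaves those two compounds unseparated. No evidence bearing on these results is available.

Going by these compounds, whether an amine or a carboxylic acid at this position would give a step beyond the scatter remains open. So does whether any replacement of the aryl group on the carbonyl carbon would separate from these three compounds.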